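The source may report more compounds than this note shows. Statements on the series, on what has been measured and on what is new or still open speak of the compounds shown alone.

Measured in a functional assay on NCI-H1975 cells (Homo sapiens) for antiproliferative activity, read by CCK-8 assay, with a stated time of 72 h; on this read-out higher numbers stand for weaker inhibition of growth and lower numbers for stronger inhibition of growth:
compound 1 `CCC1C(=O)N(C)c2cnc(-n3ccc4cc(C(=O)NCC(C)C)ccc43)nc2N1c1ccn(C)n1`: 10200 nM
compound 2 `CCC1C(=O)N(C)c2cnc(-n3ccc4cc(C(=O)NC5CCCC5)ccc43)nc2N1c1ccn(C)n1`: "not active" (no number reported)

Compound 2 has no number to place it on the scale, since compound 2 was reported as "not active" (no number reported) in this assay. Compound 1, which carries a different group on its amide nitrogen, gives 10200 nM. Among the compounds with values here, compound 3 `CCC1C(=O)N(C)c2cnc(-n3ccc4cc(C(N)=O)ccc43)nc2N1c1ccn(C)n1` keeps the shared core, and the only change is hydrogen in place of cyclopentyl on an amide-type nitrogen, with hydrogen in place of cyclopentyl on an amide-type nitrogen. Within the data shown here, no measured step shows what this change does, and without a number for compound 2 the step cannot be given a firm size. A shift towards stronger inhibition of growth in this assay is expected, but only into the weak range set by compound 1 at 10200 nM. It also remains possible that no number is obtained. Compound 3 is estimated at 6000 nM, with an expected range of 1000 nM to 30000 nM.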

Compound 3, concentration for 50% growth inhibition: "not active" (no number reported)
For compound 3 the study gives words and no number; the estimate stays without a comparison.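

In this assay compound 2 and compound 3 were both reported as "not active", so no step can be read between them. No evidence bears on this result. The compounds shown leave open what replacing cyclopentyl with hydrogen on the amide-type nitrogen does to growth inhibition.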